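Chloro for Methyl on a Quaternary Ammonium Chain Series

The compounds below may be only part of what the source reports. "The series", "measured", "known", "first", "only" and "open" are said of these compounds alone.

Of the compounds shown here, three sharing one core have been measured in an assay on LX2 cells for inhibition of COL1A1 promoter (Homo sapiens), read by a luciferase reporter, with a stated time of 24 h, tested at 20 uM; on this read-out lower numbers stand for a weaker effect and higher numbers for a stronger effect at the one concentration tested. Compound 1 `CC[N+]1(CCCCCCCOc2cc(-n3cc(C(=O)Nc4cc(F)cc(F)c4)c(=O)c4ccc(N(C)C)nc43)ccc2C)CCCC1` gives 57%. Compound 2 `CC[N+]1(CCCCCCCOc2cc(-n3cc(C(=O)Nc4cc(F)cc(F)c4)c(=O)c4ccc(N(C)C)nc43)ccc2Cl)CCCC1` gives 46% in this assay, and compound 3 `Cc1ccc(-n2cc(C(=O)Nc3cc(F)cc(F)c3)c(=O)c3ccc(N(C)C)nc32)cc1OCCCCCCC[N+](C)(C)C1CCCCC1` gives 32.3%. Compound 2 differs from compound 1 by chloro in place of methyl on an aromatic carbon, a change that gave a number 11 percentage points lower from compound 1 to compound 2 (beyond the scatter). Compound 3 differs from compound 1 by a group of 9 heavy atoms (8 carbon, 1 nitrogen; one six-membered non-aromatic ring of carbon only) in place of a group of 7 heavy atoms (6 carbon, 1 nitrogen; one five-membered non-aromatic ring with 1 hetero atom), on a saturated chain carbon, seven bonds along the chain from an oxygen on an aromatic ring, which gave a number 24.7 percentage points lower from compound 1 to compound 3 (beyond the scatter), so compound 3 stands at the lowest of the three numbers. Compound 4 `CN(C)c1ccc2c(=O)c(C(=O)Nc3cc(F)cc(F)c3)cn(-c3ccc(Cl)c(OCCCCCCC[N+](C)(C)C4CCCCC4)c3)c2n1` has not yet been measured in this assay. It differs from compound 3 by chloro in place of methyl on an aromatic carbon, which is the same change as that between compound 1 and compound 2, occurring twice among these compounds. Resting on that single earlier pair, the expected step is a number 11.3 percentage points lower from compound 3 to compound 4 (beyond the scatter), a number of similar size to the one already seen. Compound 4 is therefore estimated at 21% in this assay, with a range from 8% to 35%.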

Compound 4, a percentage reported as inhibition, at one concentration (the size of the read-out at that concentration, not a potency): 37.6%
The estimate for compound 4 lay 16.6 percentage points below the measured number; measured number above the stated range.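

With the group of 9 heavy atoms at the chain end, chloro in place of methyl gave a number 5.3 percentage points higher from compound 3 to compound 4 (within the scatter), so this change did not carry over from the earlier pair as a fixed step: the same change on two cores in this assay, a number 11 percentage points lower (beyond the scatter) from compound 1 to compound 2 and a number 5.3 percentage points higher (within the scatter) from compound 3 to compound 4, 16.3 percentage points apart, beyond the scatter of two such steps Seen from the other side, the group of 9 heavy atoms in place of the group of 7 heavy atoms gave a number 8.4 percentage points lower from compound 2 to compound 4 (within the scatter) with chloro on the aromatic ring, so that change also depended on its setting: the same change on two cores in this assay, a number 24.7 percentage points lower (beyond the scatter) from compound 1 to compound 3 and a number 8.4 percentage points lower (within the scatter) from compound 2 to compound 4, 16.3 percentage points apart, beyond the scatter of two such steps Both comparisons rest on the same four compounds, so they form one observation seen from two sides, and they show neither why the steps differ nor how either change would behave at another chain end.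

The compounds shown leave open whether fluoro or methoxy on that aromatic carbon would follow the pattern of chloro. They also leave open what a piperidinium group at the chain end, a tertiary amine in place of the quaternary ammonium, or a shorter chain would do.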